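A few compounds are considered here, and "the series" means these few. Any claim that something is new, unique, unknown or untested is made for them only; others in the source may bear on it.

In an ADME assay on KB cells (Homo sapiens) for cytotoxicity, read by resazurin assay, with a stated time of 72 h (on this read-out lower numbers stand for stronger inhibition and higher numbers for weaker inhibition), compound 1 (`O=C(/C=C/c1cccnc1)c1ccccc1`) gives 7700 nM, compound 2 (`O=C(/C=C/c1cccnc1)c1ccc(Br)cc1`) gives 7900 nM and compound 3 (`COc1ccccc1C(=O)/C=C/c1cccnc1`) gives 22700 nM. Compound 2 therefore cannot be told apart from compound 1, and the number for compound 3 lies clearly higher than both.

The open question is compound 4 (`COc1ccc(C(=O)/C=C/c2cccnc2)cc1`), which has methoxy in place of bromo on an aromatic carbon, para to a large group: methoxy in place of bromo on an aromatic carbon. Going by the values given here, two measured steps bear on this change. Putting bromo in place of hydrogen gave a 1.0-fold higher number from compound 1 to compound 2 (0.01 log units; within the scatter), so compound 2 serves here as a fair stand-in for the unsubstituted compound 1. Putting methoxy in place of hydrogen gave a 2.9-fold higher number from compound 1 to compound 3 (0.47 log units; beyond the scatter), a modest rise. The structures show, however, that the methoxy of compound 3 does not stand where the methoxy of compound 4 stands, so that step can be carried over only in part. A small shift towards a higher number in this assay is expected, and it would probably stay within the scatter: a 1.3-fold higher number from compound 2 to compound 4 (0.10 log units; within the scatter). For compound 4 the estimated value is 10000 nM, with an expected range from 5000 nM to 20000 nM.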

Compound 4, half-maximal inhibitory concentration: 21700 nM
For compound 4 the middle estimate is 2.2-fold (0.34 log units) below the measured one, outside the stated range (above it).
By their numbers in this assay, from the lowest: compounds 1 and 2 (each within the scatter of the next); then compounds 4 and 3 (each within the scatter of the next).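

In this assay, methoxy para to a large group does not read like bromo at the same place: replacing bromo with methoxy gives a 2.7-fold higher number from compound 2 to compound 4 (0.44 log units; beyond the scatter), and replacing hydrogen with methoxy gives a 2.8-fold higher number from compound 1 to compound 4 (0.45 log units; beyond the scatter). Since compound 1 and compound 2 cannot be told apart, this place does not treat every replacement of hydrogen alike, and the earlier bromo step could not be taken as a guide to methoxy. Compound 3 and compound 4 also lie within the scatter of each other, so the two methoxy placements shown cannot be told apart in this read-out, but no measurement offered here accounts for the rise seen with methoxy.

The compounds shown leave open how other groups para to a large group would read, for example an amine, a carboxylic acid, a hydroxyl or a longer chain such as ethoxy. They also leave open whether methoxy would give a step of similar size on a core other than the one shared here.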